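Cyanophenyl for Difluorophenyl on the Benzylic Carbon

A few compounds are considered here, and "the series" means these few. Any claim that something is new, unique, unknown or untested is made for them only; others in the source may bear on it.

The three measured compounds share one core and differ only in the group on a saturated chain carbon bound to an aromatic nitrogen. Compound 1 `COC(=O)c1ccc(NCc2cncn2Cc2cccc(C#N)c2)cc1-c1ccccc1` carries a 3-cyanophenyl there. In a toxicity assay on NIH3T3 cells (Mus musculus) for cytotoxicity, read by resazurin assay (on this read-out lower numbers stand for an effect already at smaller amounts and higher numbers for an effect only at larger amounts of compound), compound 1 gives only a limit, > 10000 nM. Compound 2 `COC(=O)c1ccc(NCc2cncn2Cc2ccc(Cl)cc2)cc1-c1ccccc1` carries a 4-chlorophenyl, and in this assay compound 2 gives 25000 nM. Compound 3 `COC(=O)c1ccc(NCc2cncn2Cc2ccc(F)cc2F)cc1-c1ccccc1` carries a 2,4-difluorophenyl. In this assay compound 3 gives only a limit, > 1000 nM. Compound 3 thus stands at a limit rather than at a number, and one further value among the three is also a limit. Compound 4 `COC(=O)c1ccc(NCc2cncn2Cc2ccccc2C#N)cc1-c1ccccc1` differs from compound 3 in one place: 2-cyanophenyl in place of 2,4-difluorophenyl on a saturated chain carbon bound to an aromatic nitrogen. The measured steps that bear on this change are a step that the limit leaves unreadable from compound 2 to compound 3 and a step that the two limits leave unreadable from compound 1 to compound 3, and neither has a readable size, nor has a step that the limit leaves unreadable from compound 1 to compound 2. Nothing among them points to a step beyond the scatter in either direction. Compound 4 is therefore expected near 20000 nM, between 5000 nM and 80000 nM, and the expected step is a step that the limit leaves unreadable from compound 3 to compound 4.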

Compound 4, half-maximal effective concentration: 25000 nM
Beside the measured number, compound 4's estimate is 1.3-fold (0.10 log units) below it; measured number inside the range.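

In this assay the two numbers now available at this position give no change at the digits printed from compound 2 to compound 4 (within the scatter), so 2-cyanophenyl and 4-chlorophenyl on a saturated chain carbon bound to an aromatic nitrogen cannot be told apart on this read-out. Going by these compounds alone, the earlier compounds held only one number at this position and so offered no readable step at all. The steps to compound 4 from compound 1 and from compound 3 cannot be read, as each of them starts from a limit and not from a number.

From the compounds shown here alone, how far the 2,4-difluorophenyl of compound 3 and the 3-cyanophenyl of compound 1 lie from the two numbers therefore stays open. Also open, going by these compounds, is whether a group carrying an amine or a carboxylic acid at this place would leave this assay just as unchanged.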